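The source may hold more compounds than are shown below. What is called first, only, known or untested is meant among the compounds shown, and "the series" means these compounds.

Measured compounds:
Compound 1 `CCCc1ccc(NC(=O)N[C@H](C)c2ccccc2)cc1`: 35%
Compound 2 `CCOC(=O)c1ccc(NC(=O)N[C@H](C)c2ccccc2)cc1`: 92%

For the measured compounds named here, in an ADME assay on the whole organism with Oryza sativa as the target, tested at 10 uM (on this read-out lower numbers stand for a stronger effect and higher numbers for a weaker effect at the one concentration tested), compound 2 gives the higher of the two numbers measured so far, and the nearest measured neighbour is compound 1, whose single step a number 57 percentage points higher from compound 1 to compound 2 (beyond the scatter) reaches compound 2. Compound 3 `C[C@@H](NC(=O)Nc1ccc(F)cc1)c1ccccc1` differs from compound 2 in one place, (fluoro in place of ethoxycarbonyl on an aromatic carbon), on an aromatic carbon of a six-membered aromatic ring of carbon only, para to a large group. Going by the values given here, only one measured step touches this position, and it bears on the change only in part: in it ethoxycarbonyl entered in place of propyl, whereas here ethoxycarbonyl leaves and fluoro enters, a group no measured compound carries. Among the compounds with values here, since the only step known at this position is large, the loss of ethoxycarbonyl is expected to move this assay downwards, as a number 32 percentage points lower from compound 2 to compound 3 (beyond the scatter), though with wide uncertainty. Compound 3 is estimated at 60%, within a range from 30% to 90%.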

Compound 3, a percentage reported as activity, at one concentration (the size of the read-out at that concentration, not a potency): 92%
For compound 3 the middle estimate is 32 percentage points below the measured one, outside the stated range (above it).
By their numbers in this assay, from the lowest: compound 1; then compounds 2 and 3 (each within the scatter of the next).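

In this assay the exchange of ethoxycarbonyl for fluoro gives no change at the digits printed from compound 2 to compound 3 (within the scatter) so the loss of ethoxycarbonyl does not by itself lower the number, and a group of one heavy atom matches one of five at this position. The exchange of propyl for fluoro gives a number 57 percentage points higher from compound 1 to compound 3 (beyond the scatter) and this matches the step from propyl to ethoxycarbonyl, leaving compound 1 as the one that stands apart among the three. Nothing at hand explains this pattern.

The compounds shown leave open whether the low number belongs to propyl alone or extends to other carbon chains such as ethyl or butyl. They also leave open whether an amine or a carboxylic acid at this position would fall with compound 1 or with compounds 2 and 3.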